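A few compounds are considered here, and "the series" means these few. Any claim that something is new, unique, unknown or untested is made for them only; others in the source may bear on it.

Measured so far:
- compound 1 `CCCOC(=O)C1=C(C)NC(=O)NC1c1cccs1`: 1520 nM
- compound 2 `CCCOC(=O)C1=C(C)NC(=O)NC1c1ccsc1`: 201 nM

In an assay on membranes from HEK293 cells for displacement of a labelled ligand from adenosine receptor A2b (Homo sapiens), read by scintillation counting, with a stated time of 30 min (a lower number here means a stronger inhibitor, a higher number a weaker inhibitor), compound 1 gives 1520 nM and compound 2 gives 201 nM. Within the data shown here, the single measured step, a 7.6-fold lower number from compound 1 to compound 2 (0.88 log units; beyond the scatter), is the change of thiophen-3-yl in place of thiophen-2-yl on a saturated ring carbon. Compound 2 thus stands at the lowest of the two numbers, with compound 1 as its nearest neighbour at a higher value, beyond the scatter.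

Compound 3 `CC1=C(C(=O)CC(C)C)C(c2ccsc2)NC(=O)N1` is not yet measured. It differs from compound 2 by isobutyl in place of propoxy on a carbonyl carbon — isobutyl in place of propoxy on a carbonyl carbon; cut one bond further out the change reads propoxycarbonyl to isobutylcarbonyl. Among the measured compounds shown here, no measured step bears on this change: the one step seen concerns the thiophenyl group and says nothing about the substituent on the carbonyl carbon. The expectation in this assay is therefore weakly founded and wide. Compound 3 is estimated at 350 nM, with a range from 80 nM to 1500 nM. This corresponds to an expected step of a 1.7-fold higher number from compound 2 to compound 3 (0.24 log units; within the scatter), which may well lie within the scatter.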

Compound 3, inhibition constant: 1000 nM
Compound 3: the middle estimate sits 2.9-fold (0.46 log units) below what was measured; measured number inside the range.
By their numbers in this assay, from the lowest: compound 2; then compounds 3 and 1 (each within the scatter of the next).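

The substituent on the carbonyl carbon matters in this assay, a point the thiophenyl step could not address: isobutyl in place of propoxy gives a 5.0-fold higher number from compound 2 to compound 3 (0.70 log units; beyond the scatter). The heavy-atom count stays the same across this change, while the hydrogen-bond acceptor count of the group falls from the one in propoxy to none in isobutyl, so a step beyond the scatter can arise without any change in that count. Nothing at hand gives a reason for the step.

Still open, on these data alone, is whether the step follows the loss of the propoxy oxygen or the branching of isobutyl, which a straight butyl chain or a propylamino group on the same carbonyl carbon would help separate. Also open, as far as these compounds go, is whether the same change gives a similar step with thiophen-2-yl on the shared core.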